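Swapping the benzyl substituent on a bile acid receptor binder

This account rests on a few compounds, and the source may have more. Where it says the series, first, only, none or still open, it means among the compounds named here.

Compound 1: `COC(=O)/C=C/c1cccc(N(Cc2ccc(/C=C/c3ccccn3)cc2)C(=O)C2CCCCC2)c1` — 309 nM
Compound 2: `COC(=O)/C=C/c1cccc(N(Cc2ccccc2Br)C(=O)C2CCCCC2)c1` — > 1000 nM

The two compounds share a core and differ only in the group attached to the amide nitrogen through a saturated chain carbon. In an assay on isolated protein with Bile acid receptor (Homo sapiens) as the target (a lower number here means that less compound is needed, a higher number that more compound is needed for the effect), compound 1 gives 309 nM. Among the measured compounds shown here, for compound 2 this assay reports only a limit, > 1000 nM, so no number is known for it; it is the one value of the two that sits at the limit of > 1000 nM in this assay, at which 1 of the 2 values shown sits.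

The next compound, compound 3 `COC(=O)/C=C/c1cccc(N(Cc2ccc(C(C)(C)C)cc2)C(=O)C2CCCCC2)c1`, has not yet been measured. It differs from compound 2 by 4-(tert-butyl)phenyl in place of 2-bromophenyl on a saturated chain carbon bound to an amide-type nitrogen. For the measured compounds named here, with compound 2 known only as a limit, no measured step is available to gauge the change. The expected outcome is a gain, with the step from compound 2 to compound 3 estimated at an at least 1.2-fold lower number from compound 2 to compound 3 (0.09 log units; that floor lies within the scatter), since compound 1 carries a different substituted benzyl group and gives 309 nM. Compound 3 is therefore expected to give about 800 nM in this assay, with an estimated range from 200 nM to 3000 nM; the upper part of that range would again appear only as a limit.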

Compound 3, half-maximal effective concentration: > 1000 nM
Compound 3: a limit, no number; the forecaster's own chance of this, stated with the estimate: 40%; at least 1.2-fold (0.09 log units) between middle value and limit.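

Among the compounds shown here, compound 3 gives the first readable comparison at this position. In this assay, tert-butyl in place of 2-(pyridin-2-yl)ethenyl on an aromatic carbon gives an at least 3.2-fold higher number from compound 1 to compound 3 (0.51 log units; beyond the scatter), so a bulky carbon-only group does not keep the value of compound 1, at least with tert-butyl as the example. The step between compound 2 and compound 3 cannot be read, so 2-bromophenyl and 4-(tert-butyl)phenyl cannot be ranked against each other, and compound 1 remains the only one of the three with an actual number: the limit of > 1000 nM in this assay, at which 2 of the 3 values shown sit.

On these data alone, what remains open is which part of the 2-(pyridin-2-yl)ethenyl group carries the difference, the pyridine ring or the ethenyl link; a 2-phenylethenyl group or a saturated 2-(pyridin-2-yl)ethyl chain in the same place would separate the two. How far compound 2 and compound 3 lie beyond their limits is also unknown, and so is whether the same step would hold with a group other than cyclohexyl on the amide carbonyl.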